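The source may report more compounds than this note shows. Statements on the series, on what has been measured and on what is new or still open speak of the compounds shown alone.

In a functional assay on MDA-MB-231 cells (Homo sapiens) for antiproliferative activity, read by luminescence, with a stated time of 24 h (on this read-out higher numbers stand for weaker inhibition and lower numbers for stronger inhibition), compound 1 `Cc1cc(C)c2c(c1C)OC(C)(COc1ccc(/C=C3\SC(=O)NC3=O)cc1)CC2` gives 10800 nM. Compound 2 `Cc1c(C)c2c(c(C)c1OC(=O)CCC(=O)O)CCC(C)(COc1ccc(/C=C3\SC(=O)NC3=O)cc1)O2` gives > 25000 nM, which is a limit of the assay and not a number. Going by the values given here, compound 3 `Cc1c(C)c2c(c(C)c1OC(=O)CCCC[C@@H]1SC[C@@H]3NC(=O)N[C@@H]31)CCC(C)(COc1ccc(/C=C3\SC(=O)NC3=O)cc1)O2` gives 3500 nM, the lowest value so far, and the gap up to compound 1 lies beyond the scatter.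

Compound 4 `Cc1c(C)c2c(c(C)c1OC(=O)CCCCCCCN)CCC(C)(COc1ccc(/C=C3\SC(=O)NC3=O)cc1)O2` has not yet been measured. Its difference from compound 3 is a group of 4 heavy atoms (3 carbon, 1 nitrogen; no ring) in place of a group of 9 heavy atoms (5 carbon, 2 nitrogen, 1 oxygen, 1 sulfur; one five-membered non-aromatic ring with 1 hetero atom, one five-membered non-aromatic ring with 2 hetero atoms), on a saturated chain carbon, four bonds along the chain from a carbonyl carbon. The change sits on a saturated chain carbon, four bonds along the chain from a carbonyl carbon.

Among the compounds with values here, two measured steps bear on this. The nearer one is an at least 7.1-fold lower number from compound 2 to compound 3 (0.85 log units; beyond the scatter), which also changes the far end of the chain and shows that this end can shift the number in this assay. The other is an at least 2.3-fold higher number from compound 1 to compound 2 (0.36 log units; beyond the scatter), which shows the effect of adding an ester chain. Both steps run through the limit, so each gives only a minimum size. Neither involves a 3-aminopropyl group, so they do not fix a direction for the new change, and the expectation stays close to compound 3 at 3500 nM. The expected change is a 1.3-fold higher number from compound 3 to compound 4 (0.11 log units; within the scatter), with no shift beyond the scatter as the best guess. The value estimated for compound 4 is 4500 nM, within an expected range of 1500 nM to 14000 nM.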

Compound 4, half-maximal inhibitory concentration: 5000 nM
Compound 4: middle estimate off by 1.1-fold (0.05 log units), on the low side; the range from low to high includes it.
By their numbers in this assay, from the lowest: compounds 3 and 4 (each within the scatter of the next); then compound 1. At a limit, above all of these: compound 2.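

In this assay, the saturated chain carbon four bonds along the chain from a carbonyl carbon takes 3-aminopropyl in place of the group with two five-membered non-aromatic rings and 3 defined stereocentres, and the result is a 1.4-fold higher number from compound 3 to compound 4 (0.15 log units; within the scatter); at this position, then, the two rings are not required for a number at this level. The ester chain also proves able to go either way, depending on its far end: with 5-aminopentyl in place of carboxy the result is an at least 5.0-fold lower number from compound 2 to compound 4 (0.69 log units; beyond the scatter), and adding the amine-ended chain to the core gives a 2.2-fold lower number from compound 1 to compound 4 (0.33 log units; beyond the scatter), whereas the acid-ended chain of compound 2 gave no such drop. Compound 2 stands at a limit of the assay and not a number, so its step gives only a minimum size: the limit of > 25000 nM in this assay, at which 1 of the 4 values shown sits.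

Compound 4 and compound 2 differ in both chain length and chain end, so the share of the amine itself stays unresolved. Open too, going by these compounds, is how a shorter or longer amine chain, or this same chain ending in a hydroxyl group or a methyl group, would read in this assay.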